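The source may report more compounds than this note shows. Statements on the series, on what has been measured and on what is new or still open speak of the compounds shown alone.

Compound 1 `CCN(CC)S(=O)(=O)c1ccc(S(=O)(=O)N2CCC[C@@H](C(=O)NC3COC3)C2)cc1` gives 13800 nM in a functional assay on BXPC-3 cells (Homo sapiens) for inhibition, read by MTT assay, with a stated time of 7 days; a lower number here means a stronger inhibitor, a higher number a weaker inhibitor.
Compound 2 `CCN(CC)S(=O)(=O)c1ccc(S(=O)(=O)N2CCC[C@@H](C(=O)NC3CCOCC3)C2)cc1` gives 8570 nM in this assay.
Compound 3 `CCN(CC)S(=O)(=O)c1ccc(S(=O)(=O)N2CCC[C@@H](C(=O)N[C@H]3CCOC3)C2)cc1` gives 5270 nM in this assay.

Compound 3 has the lowest of the three numbers in this assay; the nearer step is a 1.6-fold lower number from compound 2 to compound 3 (0.21 log units; within the scatter), which does not separate the two, while the further step is a 2.6-fold lower number from compound 1 to compound 3 (0.42 log units; beyond the scatter). Compound 4 `CCN(CC)S(=O)(=O)c1ccc(S(=O)(=O)N2CCC[C@@H](C(=O)N3CCC(C(F)(F)F)CC3)C2)cc1` differs from compound 3 by 4-(trifluoromethyl)piperidin-1-yl in place of (oxolan-3-yl)amino on a carbonyl carbon. Among the compounds with values here, none of the measured steps makes this change: each of them only swaps one cyclic ether for another on the amide-type nitrogen, with a 1.6-fold lower number from compound 1 to compound 2 (0.21 log units; within the scatter), a 2.6-fold lower number from compound 1 to compound 3 (0.42 log units; beyond the scatter) and a 1.6-fold lower number from compound 2 to compound 3 (0.21 log units; within the scatter), so they show that this position tolerates changes of ring size with little movement in the numbers. The move to a 4-(trifluoromethyl)piperidin-1-yl removes the hydrogen-bond donor and the hydrogen-bond acceptor of the leaving group, a larger departure than any measured step, so the measured steps give only weak guidance. Compound 4 is therefore expected to stay near the range of the measured compounds, with an estimated step of a 1.3-fold higher number from compound 3 to compound 4 (0.12 log units; within the scatter) and a wide uncertainty. The estimate for compound 4 in this assay is 7000 nM, with a range from 2000 nM to 25000 nM.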

Compound 4, half-maximal inhibitory concentration: 370 nM
Beside the measured number, compound 4's estimate is 19-fold (1.28 log units) above it; the whole stated range lies above it.
By their numbers in this assay, from the lowest: compound 4; then compounds 3, 2 and 1 (each within the scatter of the next, the first and the last beyond it).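

In this assay the swaps among cyclic ethers had moved the number only modestly at most, but 4-(trifluoromethyl)piperidin-1-yl on this carbonyl carbon gives a 14-fold lower number from compound 3 to compound 4 (1.15 log units; beyond the scatter) and a 23-fold lower number from compound 2 to compound 4 (1.36 log units; beyond the scatter) and also a 37-fold lower number from compound 1 to compound 4 (1.57 log units; beyond the scatter) so this position can change the number far more than those swaps suggested. All three steps lie beyond the scatter and run the same way, which makes compound 4 the strongest inhibitor of the four and shows that the position is sensitive to the group placed there as well as tolerant of changes in ether ring size. The change alters several things at once, since the entering group has more heavy atoms, fluorine in place of oxygen and neither a hydrogen-bond donor nor a hydrogen-bond acceptor, and no measurement here says which of these accounts for the result.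

From the compounds shown here alone, it remains open whether the gain depends on the trifluoromethyl group or on the piperidine ring, a question that plain piperidin-1-yl or 4-methylpiperidin-1-yl on the same carbonyl carbon would address. A 4-(trifluoromethyl)cyclohexyl group on an amide that keeps the amide hydrogen would show whether losing that hydrogen matters.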